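Methyl Placement on Two Cores in Ovarian Cell Cytotoxicity

The compounds below may be only part of what the source reports. "The series", "measured", "known", "first", "only" and "open" are said of these compounds alone.

Compound 1 `C/C(=C\c1cc(-c2ccccc2)co1)C(N)=O` gives 42400 nM in a functional assay on HO8910 cells (Homo sapiens) for cytotoxicity, read by CCK-8 assay, with a stated time of 24 h; a higher number here means a weaker inhibitor, a lower number a stronger inhibitor. Compound 2 `C/C(=C\c1cc(-c2ccc(C)cc2)co1)C(N)=O` differs by methyl in place of hydrogen on an aromatic carbon, and in this assay compound 2 gives 24200 nM, a step of a 1.8-fold lower number from compound 1 to compound 2 (0.24 log units; within the scatter). Compound 3 `C/C(=C\c1cc(-c2ccccc2)cs1)C(N)=O` is built on a different core, and the difference between the two cores is not broken down here. In this assay compound 3 gives only a limit, > 50000 nM. Compound 4 `C/C(=C\c1cc(-c2ccccc2C)cs1)C(N)=O` carries methyl in place of hydrogen on an aromatic carbon; this is the same kind of change as that made to reach compound 2, though here the methyl sits ortho to a large group rather than para to a large group. Resting on the small step of a 1.8-fold lower number from compound 1 to compound 2 (0.24 log units; within the scatter), the step in this assay is expected to be a step that the limit leaves unreadable from compound 3 to compound 4. Compound 4 is therefore estimated at 60000 nM, between 25000 nM and 150000 nM, with a real chance that it again sits at the limit of > 50000 nM in this assay, at which 1 of the 3 values shown sits.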

Compound 4, half-maximal inhibitory concentration: 15200 nM
The estimate for compound 4 lay 3.9-fold (0.60 log units) above the measured number; measured number below the stated range.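

On the core of compound 3, methyl in place of hydrogen, here ortho to a large group, gives an at least 3.2-fold lower number from compound 3 to compound 4 (0.51 log units; beyond the scatter) in this assay. Compound 3 gives > 50000 nM, which is a limit and not a number. So this change has a clear effect on this core, but the data do not show that its size carries over from one core to the other, and the methyl also sits at a different place on the ring in each pair: the same change on two cores in this assay, a 1.8-fold lower number (0.24 log units; within the scatter) from compound 1 to compound 2 and an at least 3.2-fold lower number (0.51 log units; beyond the scatter) from compound 3 to compound 4; the limit leaves it open whether they differ

The compounds shown leave open how a methyl would act at the same place on both cores. They also leave open whether a different group, such as a methoxy group, a chlorine atom or an amine, would give a similar step.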